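This account rests on a few compounds, and the source may have more. Where it says the series, first, only, none or still open, it means among the compounds named here.

Within the data shown here, in an assay on NIH3T3 cells for displacement of a labelled ligand from melatonin receptor type 1A (Homo sapiens), with a stated time of 90 min (on this read-out higher numbers stand for weaker inhibition and lower numbers for stronger inhibition), two compounds have a number so far, and compound 2 `COc1ccccc1OC(C)CNC(C)=O` stands lowest of them; in this assay compound 2 gives 10500 nM. The other measured compound is compound 1 `COc1ccc(OC(C)CNC(C)=O)cc1`, which in this assay gives 42700 nM, a higher number than that of compound 2 by more than the usual scatter of repeated measurements, so compound 2 is the stronger binder of the two. Both share the same side chain attached to the aromatic ring.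

Compound 3 `CC(=O)NCC(C)Oc1ccccc1` has not yet been measured. It is obtained from compound 2 by a single change: hydrogen in place of methoxy on an aromatic carbon. Among the measured compounds shown here, no measured pair shows this exact change, so the size of the step cannot be read from the data directly. Because compound 1 gives 42700 nM while compound 2 gives 10500 nM, the methoxy group clearly matters for the number, and taking it away is expected to move the number upward rather than leave it unchanged. The estimate implies an expected step of a 2.4-fold higher number from compound 2 to compound 3 (0.38 log units; beyond the scatter), a modest loss of binding beyond the scatter. Compound 3 is therefore expected to give about 25000 nM, within a range from 8000 nM to 80000 nM.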

Compound 3, inhibition constant: 1380 nM
Compound 3: the middle estimate sits 18-fold (1.26 log units) above what was measured; measured number outside the range, below it.
By their numbers in this assay, from the lowest: compound 3; then compound 2; then compound 1.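

In this assay, putting hydrogen in place of methoxy on an aromatic carbon, ortho to a group of 8 heavy atoms, improves the number rather than worsening it: the change gives a 7.6-fold lower number from compound 2 to compound 3 (0.88 log units; beyond the scatter). The same exchange at the aromatic carbon that carries the methoxy in compound 1 gives a 31-fold lower number from compound 1 to compound 3 (1.49 log units; beyond the scatter), so neither methoxy placement shown here does better than plain hydrogen on the ring, and in these compounds the methoxy group counts against binding wherever it sits. Nothing measured alongside these numbers accounts for this direction of change.

These three compounds leave open whether methoxy is a special case or whether other groups on the ring, such as a fluorine atom, a chlorine atom, a methyl or a hydroxyl, would also give a higher number than compound 3 does. On these data alone, the side chain is the same throughout, so it also remains open how the number would respond to a longer chain on the amide carbonyl or to an amine in place of the amide.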